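The compounds below may be only part of what the source reports. "The series", "measured", "known", "first", "only" and "open" are said of these compounds alone.

Measured so far in a functional assay on NCI-H1975 cells (Homo sapiens) for inhibition, read by MTT assay, with a stated time of 72 h; on this read-out lower numbers stand for stronger inhibition and higher numbers for weaker inhibition:

compound 1, `O=C(CSc1nc(Nc2ccccc2)c2ccccc2n1)Nc1cccc(F)c1`: 6790 nM
compound 2, `O=C(CSc1nc(Nc2ccccc2)c2ccccc2n1)Nc1cccc(Br)c1`: 10100 nM

Among the measured compounds shown here, compound 1 holds the lower of the two numbers, but its only neighbour is compound 2, and the step of a 1.5-fold higher number from compound 1 to compound 2 (0.17 log units; within the scatter) stays within the scatter, so the two cannot be told apart in this assay.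

Compound 3, `O=C(CSc1nc(Nc2ccccc2)c2ccccc2n1)Nc1ccc(F)cc1`, has not been measured in this assay. It differs from compound 1 by 4-fluorophenyl in place of 3-fluorophenyl on an amide-type nitrogen. For the measured compounds named here, no measured step moves the fluorine to another place on that ring. Going by the values given here, the one step available, a 1.5-fold higher number from compound 1 to compound 2 (0.17 log units; within the scatter), exchanges the halogen at its original place and produces nothing beyond the scatter, which is the only hint on how this part of the molecule responds to change. The step from compound 1 to compound 3 is therefore expected to stay within the scatter: a 1.0-fold higher number from compound 1 to compound 3 (0.01 log units; within the scatter). In this assay compound 3 is expected at 7000 nM, with a range from 2500 nM to 20000 nM.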

Compound 3, half-maximal inhibitory concentration: 16500 nM
Compound 3: the middle estimate sits 2.4-fold (0.37 log units) below what was measured; low and high end bracket the measured number.
By their numbers in this assay, from the lowest: compounds 1, 2 and 3 (each within the scatter of the next, the first and the last beyond it).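

In this assay, among the compounds shown here, the change from 3-fluorophenyl to 4-fluorophenyl on the amide-type nitrogen is the first step to pass the scatter, though only modestly (a 2.4-fold higher number from compound 1 to compound 3 (0.39 log units; beyond the scatter)). The place of the fluorine on this ring therefore registers in the read-out, whereas the exchange of halogen at the original place did not separate compound 1 from compound 2. The difference does not extend to every pair, as compound 3 stays within the scatter of compound 2 (a 1.6-fold higher number from compound 2 to compound 3 (0.21 log units; within the scatter)).

Still open, going by these compounds, is how a phenyl ring without a halogen, or one carrying a methoxy group or a carboxylic acid, would read on this nitrogen, and whether 4-bromophenyl would follow 4-fluorophenyl. Nothing available bears on what lies behind the difference between compound 1 and compound 3.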